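Sulfonyl ring variation on the dichlorobenzyl pyrazole core

The source may hold more compounds than are shown below. What is called first, only, known or untested is meant among the compounds shown, and "the series" means these compounds.

Within the data shown here, in an assay on isolated protein for displacement of a labelled ligand from prostaglandin E2 receptor EP3 subtype (Homo sapiens), read by scintillation counting, with a stated time of 2 h (a lower number here means a stronger inhibitor, a higher number a weaker inhibitor), compound 2 `O=C(NC/C=C1\CCCc2cnn(Cc3ccc(Cl)cc3Cl)c21)NS(=O)(=O)c1cc(Cl)c(Cl)s1` gives 0.5 nM, the lowest of the two numbers measured so far; the move a 4.0-fold lower number from compound 1 to compound 2 (0.60 log units; beyond the scatter) puts it beyond the scatter from compound 1 `Cc1nc(C)c(S(=O)(=O)NC(=O)NC/C=C2\CCCc3cnn(Cc4ccc(Cl)cc4Cl)c32)s1`, which gives 2 nM. Compound 3 `O=C(NC/C=C1\CCCc2cnn(Cc3ccc(Cl)cc3Cl)c21)NS(=O)(=O)c1cccs1` carries thiophen-2-yl in place of 4,5-dichlorothiophen-2-yl on a sulfonyl sulfur. Among the measured compounds shown here, no measured step strips chlorine from a ring that is otherwise kept; the only step on this sulfonyl sulfur exchanges whole rings, so it bears on this change only loosely. A modest rise in this assay is therefore expected, a 3.0-fold higher number from compound 2 to compound 3 (0.48 log units; beyond the scatter). Compound 3 is estimated at 1.5 nM, within 0.5 nM to 5 nM.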

Compound 3, inhibition constant: 15 nM
Beside the measured number, compound 3's estimate is 10-fold (1.00 log units) below it; measured number outside the range, above it.
By their numbers in this assay, from the lowest: compound 2; then compound 1; then compound 3.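

In this assay, losing both chlorines from the thiophene ring is a large step (a 30-fold higher number from compound 2 to compound 3 (1.48 log units; beyond the scatter)), so on this sulfonyl sulfur the low number of compound 2 depends on the 4,5-dichlorothiophen-2-yl group and not on the thiophene ring alone. The unsubstituted ring also falls short of 2,4-dimethyl-1,3-thiazol-5-yl (a 7.5-fold higher number from compound 1 to compound 3 (0.88 log units; beyond the scatter)), so both substituted rings give lower numbers than thiophen-2-yl. Nothing available explains the size of these steps.

From the compounds shown here alone, whether a single chlorine, as in 5-chlorothiophen-2-yl, recovers most of the loss remains open. So does whether a methyl group on the thiophene or a 3,4-dichlorophenyl ring would serve equally well.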